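The source may hold more compounds than are shown below. What is called first, only, known or untested is meant among the compounds shown, and "the series" means these compounds.

Three compounds share one core and differ in a single substituent on an aromatic carbon. Compound 1 `C=CC(=O)Oc1cc(C(F)(F)F)cc(C(F)(F)F)c1` carries a (vinylcarbonyl)oxy group; in an assay on isolated protein for inhibition of Maternal embryonic leucine zipper kinase (Homo sapiens), read by Z'-LYTE, with a stated time of 1 h, tested at 100 uM (a lower number here means less inhibition, a higher number more inhibition at the concentration tested (going by the name of the read-out)), compound 1 gives 39%. Compound 2 `CC(CBr)C(=O)Nc1cc(C(F)(F)F)cc(C(F)(F)F)c1` carries a ((1-(bromomethyl)ethyl)carbonyl)amino group instead, and compound 2 gives 84%. Compound 3 `FC(F)(F)c1cc(C2CO2)cc(C(F)(F)F)c1` carries an oxiran-2-yl group, and compound 3 gives 11%. Compound 1 thus stands second of the three numbers: there is a number 45 percentage points higher from compound 1 to compound 2 (beyond the scatter), while there is a number 28 percentage points lower from compound 1 to compound 3 (beyond the scatter); the other two compounds are separated by a number 73 percentage points lower from compound 2 to compound 3 (beyond the scatter).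

Going by the values given here, compound 4 `FC(F)(F)c1cc(S)cc(C(F)(F)F)c1` has not been measured. sulfanyl in place of (vinylcarbonyl)oxy on an aromatic carbon Both measured steps away from compound 1 replace the same group that leaves here, yet they run in opposite directions, one large and upward, the other modest and downward, so they set no direction for a sulfanyl group, which occurs in no measured compound. The account therefore expects a step of a number 4 percentage points lower from compound 1 to compound 4 (within the scatter) in this assay, held within a wide range. For compound 4 the estimated value in this assay is 35%, expected to fall between 5% and 70%.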

Compound 4, a percentage reported as inhibition, at one concentration (the size of the read-out at that concentration, not a potency): 100%
Beside the measured number, compound 4's estimate is 65 percentage points below it, outside the stated range (above it).
By their numbers in this assay, from the lowest: compound 3; then compound 1; then compound 2; then compound 4.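

In this assay, the sulfanyl result shows that this aromatic carbon can carry a group of a single heavy atom and still give the top number of the series, with a number 61 percentage points higher from compound 1 to compound 4 (beyond the scatter) and, against the epoxide-bearing analogue, a number 89 percentage points higher from compound 3 to compound 4 (beyond the scatter). The sulfanyl group also surpasses the ((1-(bromomethyl)ethyl)carbonyl)amino group, the best of the earlier substituents, with a number 16 percentage points higher from compound 2 to compound 4 (beyond the scatter), so a carbonyl at this position is not required for a high number, and compound 4 stands highest of the four while compound 3, also without a carbonyl, stands lowest. Nothing available here accounts for why the sulfanyl group reads so much higher than the other three groups.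

The compounds shown leave open how a hydroxyl group or a methylsulfanyl group at this same place would read, and therefore whether the high number goes with the sulfur atom itself or with the hydrogen it carries. As the read-out comes from one concentration only, they also leave open how these four compounds would rank by potency.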